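Alkyne to methyl-substituted alkene in a diaryl urea series

The source may hold more compounds than are shown below. What is called first, only, known or untested is meant among the compounds shown, and "the series" means these compounds.

Three diaryl ureas sharing one core have been measured in a functional assay on A-375 cells (Homo sapiens) for inhibition, read by MTT assay, with a stated time of 120 h; on this read-out higher numbers stand for weaker inhibition and lower numbers for stronger inhibition. Compound 1 `CC(NC(=O)/C=C/Oc1ccc(NC(=O)Nc2cc(C(F)(F)F)ccc2Cl)cc1)c1ccccc1` gives 16000 nM. Compound 3 `CC(NC(=O)c1cccc(-c2ccc(NC(=O)Nc3ccc(Cl)c(C(F)(F)F)c3)cc2)c1)c1ccccc1` gives 5170 nM. Compound 2 `CNC(=O)C#Cc1ccc(NC(=O)Nc2ccc(Cl)c(C(F)(F)F)c2)cc1` gives only > 50000 nM, which is a limit of the assay and not a number. Compound 2 therefore stands at the weak end of the three, at the limit of > 50000 nM in this assay, at which 1 of the 3 values shown sits, while compound 1 and compound 3 both give measurable numbers.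

Compound 4 `CNC(=O)/C(C)=C/c1ccc(NC(=O)Nc2ccc(Cl)c(C(F)(F)F)c2)cc1` has not been measured. It differs from compound 2 in one place: 2-(methylcarbamoyl)prop-1-en-1-yl in place of 2-(methylcarbamoyl)ethynyl on an aromatic carbon. The linker keeps its single hydrogen-bond donor and acceptor and gains one heavy atom, a methyl on the unsaturated chain, while the triple bond becomes a double bond.

Within the data shown here, no step between measured compounds covers this change, so any expectation rests on the three values alone. With compound 2 at a limit, the step from compound 2 to compound 4 can only be judged loosely; a modest gain toward the range of compound 1 is expected, but a second limit would not be surprising. Compound 4 is estimated at 30000 nM, between 8000 nM and 100000 nM, an expected step of an at least 1.6-fold lower number from compound 2 to compound 4 (0.22 log units; that floor lies within the scatter).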

Compound 4, half-maximal inhibitory concentration: > 50000 nM
Compound 4: a limit, no number (the forecaster's own chance of this, stated with the estimate: 40%); at least 1.6-fold (0.22 log units) between middle value and limit.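

Compound 4, like compound 2, gives a limit of the assay and not a number, so no step from compound 2 to compound 4 can be read: the limit of > 50000 nM in this assay, at which 2 of the 4 values shown sit.

The compounds shown leave open whether 2-(methylcarbamoyl)prop-1-en-1-yl or 2-(methylcarbamoyl)ethynyl on the shared core gives the lower number in this assay.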